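Chloro for methyl on an aryl triazole substituent

This account rests on a few compounds, and the source may have more. Where it says the series, first, only, none or still open, it means among the compounds named here.

Compound 2 `Cc1ccc(Cl)cc1-n1nncc1CN1C(=O)C2(C(C#N)=C(N)Oc3c2c2nc4ccccc4nc2c2ccccc32)c2ccccc21` is one of two close analogues measured in an ADME assay on HUVEC cells (Homo sapiens) for antiproliferative activity, read by MTT assay, with a stated time of 48 h; on this read-out higher numbers stand for weaker inhibition and lower numbers for stronger inhibition. Its value of > 50000 nM is a limit of the assay, not a number. Compound 1 `N#CC1=C(N)Oc2c(c3nc4ccccc4nc3c3ccccc23)C12C(=O)N(Cc1cnnn1-c1ccccc1Br)c1ccccc12` likewise gives > 50000 nM in this assay, again a limit. Among the compounds with values here, the one step between them, a step that the two limits leave unreadable from compound 1 to compound 2, cannot be sized for this reason, and the only evidence on measured steps is the limit of > 50000 nM in this assay, at which 2 of the 2 values shown sit. Compound 3 `N#CC1=C(N)Oc2c(c3nc4ccccc4nc3c3ccccc23)C12C(=O)N(Cc1cnnn1-c1cc(Cl)ccc1Cl)c1ccccc12` carries the change (chloro in place of methyl on an aromatic carbon), a chloro in place of methyl on an aromatic carbon. Within the data shown here, no measured step bears on this exchange, and the two limits give no direction. The step from compound 2 to compound 3 is therefore expected as a step that the limit leaves unreadable from compound 2 to compound 3, with compound 3 most likely ending at a limit again. For compound 3 the estimate in this assay is 60000 nM, within 20000 nM to 200000 nM.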

Compound 3, half-maximal inhibitory concentration: > 50000 nM
Compound 3 ended at the assay's limit; the forecaster's own chance of this, stated with the estimate: 85%; the middle value is on the limit's open side.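

No step among compound 1, compound 2 and compound 3 can be read in this assay, since each value is a limit and not a number: the limit of > 50000 nM in this assay, at which 3 of the 3 values shown sit.

These compounds leave open whether any exchange on the phenyl group changes the activity at all, and in which direction.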